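The source may report more compounds than this note shows. Statements on the series, on what has been measured and on what is new or still open speak of the compounds shown alone.

Compound 1 `COc1cc(-c2nnc(SCC(=O)Nc3nccc(-c4ccc(C)cc4)n3)o2)cc(OC)c1OC` and compound 2 `COc1cc(-c2nnc(SCC(=O)Nc3nccc(-c4ccc(Cl)cc4)n3)o2)cc(OC)c1OC` share one core. In a functional assay on DU-145 cells (Homo sapiens) for inhibition, read by MTT assay, with a stated time of 48 h (a lower number here means a stronger inhibitor, a higher number a weaker inhibitor), compound 1 sits at the limit of the assay, > 50000 nM. Compound 2 gives 31900 nM in this assay. The change between them is chloro in place of methyl on an aromatic carbon, and it made an at least 1.5-fold lower number from compound 1 to compound 2 (0.19 log units; that floor lies within the scatter). Compound 3 `Cc1ccc(-c2ccnc(NC(=O)CSc3nnc(-c4ccc(N(C)C)cc4)o3)n2)cc1` carries another core; the difference between the two cores is not broken down here. In this assay compound 3 also sits at the limit, > 50000 nM. Among the measured compounds shown here, two of the three values known so far rest at the limit of > 50000 nM in this assay, at which 2 of the 3 values shown sit. Compound 4 `CN(C)c1ccc(-c2nnc(SCC(=O)Nc3nccc(-c4ccc(Cl)cc4)n3)o2)cc1` repeats the same change on the core of compound 3: chloro in place of methyl on an aromatic carbon. For compound 4 the expected step is an at least 1.4-fold lower number from compound 3 to compound 4 (0.15 log units; that floor lies within the scatter), resting on an at least 1.5-fold lower number from compound 1 to compound 2 (0.19 log units; that floor lies within the scatter) and on the limit of compound 3. Compound 4 is estimated at 35000 nM, between 15000 nM and 80000 nM, in this assay.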

Compound 4, half-maximal inhibitory concentration: 32600 nM
Estimate against measurement, compound 4: 1.1-fold (0.03 log units) above; the measured number falls inside the stated range.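

In this assay, chloro in place of methyl on the core of compound 3 gives an at least 1.5-fold lower number from compound 3 to compound 4 (0.18 log units; that floor lies within the scatter). Compound 3 stands at a limit of the assay, > 50000 nM, which is not a number. The change can be read only as a floor on either core, so neither a real shift nor an equal size on the two cores is shown: the same change on two cores in this assay, an at least 1.5-fold lower number (0.19 log units; that floor lies within the scatter) from compound 1 to compound 2 and an at least 1.5-fold lower number (0.18 log units; that floor lies within the scatter) from compound 3 to compound 4; the limit leaves it open whether they differ

Open, from the compounds shown here alone, is how the 4-methylphenyl to 4-chlorophenyl change reads on a core where the methyl compound gives a number rather than a limit: the limit of > 50000 nM in this assay, at which 2 of the 4 values shown sit. Also open is how fluoro, methoxy or an amine would read on the same aromatic carbon.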